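The source may hold more compounds than are shown below. What is called first, only, known or untested is meant among the compounds shown, and "the series" means these compounds.

Of the compounds shown here, two have been measured so far. Compound 1 `Cc1nc(C)c(C(=O)Oc2ccccc2/C=C/C(=O)O)nc1C` gives 80.1% in a functional assay on EA.hy 926 cells (Homo sapiens) for cytotoxicity, read by MTT assay, with stated times of 24 h and 12 h, tested at 100 uM (on this read-out higher numbers stand for a stronger effect at the one concentration tested and lower numbers for a weaker effect), while compound 2 `COc1ccc(/C=C/C(=O)O)c(OC(=O)c2nc(C)c(C)nc2C)c1` gives 18%. Going by the values given here, the single step connecting them, a number 62.1 percentage points lower from compound 1 to compound 2 (beyond the scatter), leaves compound 2 standing at the lower of the two numbers, with compound 1 the nearest and higher value.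

The next compound, compound 3 `CCOC(=O)/C=C/c1ccc(OC)cc1OC(=O)c1nc(C)c(C)nc1C`, differs from compound 2 in one place: ethyl in place of hydrogen on an oxygen next to a carbonyl group. Among the compounds with values here, none of the measured steps bears on this change; the only step known concerns a methoxy group on an aromatic carbon, not an ester formed at the carboxylic acid. Within the data shown here, there is therefore no precedent from which to read a direction or a size for the present step in this assay.

In the absence of such a precedent, compound 3 is expected to stay close to compound 2, and the estimated step is a number 7 percentage points higher from compound 2 to compound 3 (within the scatter), judged not to exceed the scatter. Compound 3 is accordingly estimated at 25%, with a range from 5% to 55%.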

Compound 3, a percentage reported as activity, at one concentration (the size of the read-out at that concentration, not a potency): 39.9%
Beside the measured number, compound 3's estimate is 14.9 percentage points below it, within the range that was stated.
By their numbers in this assay, from the lowest: compound 2; then compound 3; then compound 1.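

In this assay, going by these compounds alone, the change from carboxy to ethoxycarbonyl, with ethyl in place of hydrogen on an oxygen next to a carbonyl group, gives a number 21.9 percentage points higher from compound 2 to compound 3 (beyond the scatter), which shows that the number also responds to a change at this position, whereas the earlier compounds showed only a change on an aromatic carbon. Within the data shown here, this step runs upward, while the one earlier step, a number 62.1 percentage points lower from compound 1 to compound 2 (beyond the scatter), runs downward, but the two lie at different places and neither predicts the other. Nothing measured here accounts for the rise that comes with the ethyl group.

As far as these compounds go, whether methyl or a longer chain such as butyl on this oxygen would move the number in the same direction stays open, as does the effect of an amide in place of the ester. Among these compounds, it is also open whether ethyl on this oxygen would give a step of the same direction and size on compound 1, which has hydrogen where compound 2 carries methoxy, since the only reading of this change starts from compound 2.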